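This account rests on a few compounds, and the source may have more. Where it says the series, first, only, none or still open, it means among the compounds named here.

The measured compounds in a functional assay on MCF7 cells (Homo sapiens) for antiproliferative activity, read by sulforhodamine B assay, with a stated time of 48 h (a higher number here means a weaker inhibitor, a lower number a stronger inhibitor), are these

- compound 1 `COc1cc(OC)c(/C=C/C(=O)C(=Cc2ccc(O)c(OC)c2)C(=O)/C=C/c2c(OC)cc(OC)cc2OC)c(OC)c1` gives 1880 nM
- compound 2 `COc1cc(OC)c(/C=C/C(=O)C(=Cc2ccc(O)c(F)c2)C(=O)/C=C/c2c(OC)cc(OC)cc2OC)c(OC)c1` gives 3180 nM

Among the measured compounds shown here, compound 2 sits level with the only other measured compound, within the usual scatter of repeated measurements. For the measured compounds named here, the one measured step is a 1.7-fold higher number from compound 1 to compound 2 (0.23 log units; within the scatter) and it came with fluoro in place of methoxy on an aromatic carbon. The next compound to consider is compound 3 `COc1cc(OC)c(/C=C/C(=O)C(=Cc2cc(Br)c(O)c(OC)c2)C(=O)/C=C/c2c(OC)cc(OC)cc2OC)c(OC)c1` and the change that leads to it is 3-bromo-4-hydroxy-5-methoxyphenyl in place of 3-fluoro-4-hydroxyphenyl on a double-bonded chain carbon bound to a double-bonded chain carbon on a double-bonded chain carbon bound to a double-bonded chain carbon. The measured step bears on this change only in part, since it also concerned a substituent on this phenyl group and stayed within the scatter. Going by the values given here, no measured compound carries bromine, so that part of the change has no guide in the data. No step beyond the scatter is therefore expected in this assay for this change. The expected size is a 1.4-fold lower number from compound 2 to compound 3 (0.14 log units; within the scatter) and that is only an estimate. For compound 3 the estimated value is 2300 nM with an expected range from 800 nM to 6500 nM as the outcome of the measurement.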

Compound 3, half-maximal inhibitory concentration: 1460 nM
Beside the measured number, compound 3's estimate is 1.6-fold (0.20 log units) above it; the range from low to high includes it.
By their numbers in this assay, from the lowest: compounds 3, 1 and 2 (each within the scatter of the next, the first and the last beyond it).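

In this assay, the phenyl group on a double-bonded chain carbon bound to a double-bonded chain carbon now shows its first change beyond the scatter: 3-bromo-4-hydroxy-5-methoxyphenyl in place of 3-fluoro-4-hydroxyphenyl gives a 2.2-fold lower number from compound 2 to compound 3 (0.34 log units; beyond the scatter) as a modest step. Taken alone, bromo in place of hydrogen on an aromatic carbon gives a 1.3-fold lower number from compound 1 to compound 3 (0.11 log units; within the scatter) and stays within the scatter, so this phenyl group keeps its activity in this assay with a bromine added to it. The modest step therefore links the two ends of a short row whose neighbouring compounds cannot be told apart, and since that step swaps fluorine for bromine and adds a methoxy group at once, it cannot be assigned to either part.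

Still open, going by these compounds, is whether chlorine or iodine in the place of the bromine would give a similar number, and whether an amine or a carboxylic acid on this phenyl group would keep the activity. Nothing available here gives a reason for the differences seen among these three compounds.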